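The compounds below may be only part of what the source reports. "The series", "measured", "known", "first", "only" and "open" are said of these compounds alone.

For the measured compounds named here, in a functional assay on MCF7 cells (Homo sapiens) for antiproliferative activity, read by MTT assay, with a stated time of 48 h (on this read-out higher numbers stand for weaker inhibition and lower numbers for stronger inhibition), compound 2 `COc1ccc(N2CCN(C(=O)/C=C/c3ccc(O)c(O)c3)CC2)cc1` gives 0.52 ug/mL, the lower of the two numbers so far, and compound 1 `O=C(/C=C/c1ccc(O)c(O)c1)N1CCN(c2ccccc2F)CC1` gives 1.38 ug/mL. Compound 3 `O=C(/C=C/c1ccc(O)c(O)c1)N1CCN(c2ccccn2)CC1` has pyridin-2-yl in place of 4-methoxyphenyl on an amine nitrogen in a ring. Going by the values given here, one measured step bears on this change, the modest 2.7-fold lower number from compound 1 to compound 2 (0.42 log units; beyond the scatter), where 4-methoxyphenyl entered at the same place. Among the compounds with values here, no measured compound carries pyridin-2-yl, so the reasoning is thin. Losing 4-methoxyphenyl is expected to undo a similar amount, an estimated 2.3-fold higher number from compound 2 to compound 3 (0.36 log units; beyond the scatter) in this assay. For compound 3 the estimated value is 1.2 ug/mL, with an expected range of 0.4 ug/mL to 3.5 ug/mL.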

Compound 3, half-maximal inhibitory concentration: 1.82 ug/mL
Compound 3: middle estimate off by 1.5-fold (0.18 log units), on the low side; the measured number falls inside the stated range.
By their numbers in this assay, from the lowest: compound 2; then compounds 1 and 3 (each within the scatter of the next).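

In this assay the position on the amine nitrogen in the ring now holds a third group, and swapping 4-methoxyphenyl for pyridin-2-yl gives a step beyond the scatter (a 3.5-fold higher number from compound 2 to compound 3 (0.54 log units; beyond the scatter)). Pyridin-2-yl in place of 2-fluorophenyl gives a step within the scatter (a 1.3-fold higher number from compound 1 to compound 3 (0.12 log units; within the scatter)), so among these three compounds only compound 2 stands apart. No measurement shown speaks to the reason for this.

Open, on these data alone, is whether a plain phenyl or a 2-methoxyphenyl on this nitrogen would read like compound 2 or like compounds 1 and 3. As far as these compounds go, how a benzyl group would read there is also open.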